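Fluoro to chloro: estimating how much compound cells tolerate

A few compounds are considered here, and "the series" means these few. Any claim that something is new, unique, unknown or untested is made for them only; others in the source may bear on it.

Compound 1 `Nc1nc(-c2ccccc2)cc(-c2ccc(C3NC(=O)c4ccccc4N3)cc2)n1`, compound 2 `COc1cc(-c2cc(-c3ccc(C4NC(=O)c5ccccc5N4)cc3)nc(N)n2)cc(OC)c1OC`, compound 3 `Nc1nc(-c2ccc(F)cc2)cc(-c2ccc(C3NC(=O)c4ccccc4N3)cc2)n1` and compound 4 `Nc1nc(-c2ccc(Cl)cc2)cc(-c2ccc(C3NC(=O)c4ccccc4N3)cc2)n1` share one core. For the measured compounds named here, in an ADME assay on Vero cells (Chlorocebus sabaeus) for cytotoxicity, read by MTT assay, with a stated time of 72 h (a higher number here means that more compound is tolerated, a lower number that less compound is tolerated), compound 2 gives 85900 nM, the only number so far. The entry for compound 1 reads "not determined" (no result reported). The entry for compound 3 reads "not determined" (no result reported), so compound 3 offers no number to start from. The change chloro in place of fluoro on an aromatic carbon puts chloro in place of fluoro on an aromatic carbon, turning 4-fluorophenyl into 4-chlorophenyl. Going by the values given here, no measured pair shows what this swap does in this assay, so no step beyond the usual scatter is expected, and the only anchor is compound 2 at 85900 nM. Compound 4 is estimated at 70000 nM, with an expected range of 25000 nM to 200000 nM.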

Compound 4, half-maximal cytotoxic concentration: 323000 nM
Compound 4: middle estimate off by 4.6-fold (0.66 log units), on the low side, outside the stated range (above it).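

In this assay, the group at this position does change the result: 4-chlorophenyl in place of 3,4,5-trimethoxyphenyl gives a 3.8-fold higher number from compound 2 to compound 4 (0.58 log units; beyond the scatter) and so more compound is tolerated. Compound 3 has no number, so the fluoro-to-chloro swap itself cannot be read. Nothing measured here explains the step.

Going by these compounds, whether the gain comes from adding chlorine or from losing the methoxy groups stays open, as compound 1 has no number either. On these data alone, how an amine or a carboxylic acid would behave at this position also remains unknown.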